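Swapping the Ester Group of Compound 2

A few compounds are considered here, and "the series" means these few. Any claim that something is new, unique, unknown or untested is made for them only; others in the source may bear on it.

Compound 1 `CCc1cccc2c(O)c(-c3occ(C)c3C(=O)O)ccc12`, compound 2 `CCCOC(=O)c1c(C)coc1-c1ccc2c(CC)cccc2c1OC` and compound 3 `CCc1cccc2c(OC)c(-c3occ(C)c3C(=S)OC)ccc12` share one core and were tested in a functional assay on DU-145 cells (Homo sapiens) for cytotoxicity, read by MTT assay, with a stated time of 72 h; on this read-out higher numbers stand for an effect only at larger amounts of compound and lower numbers for an effect already at smaller amounts. In this assay compound 1 gives 8.7 ug/mL and compound 3 gives 5.7 ug/mL. For compound 2 the result is a limit of the assay rather than a number, > 10 ug/mL, as noted by the limit of > 10 ug/mL in this assay, at which 1 of the 3 values shown sits. Compound 2 therefore stands at the upper edge of what the three results show. Among the measured compounds shown here, the single measured step that starts from it is an at least 1.7-fold lower number from compound 2 to compound 3 (0.24 log units; that floor lies within the scatter), and its floor lies within the scatter.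

Compound 4 `CCc1cccc2c(OC)c(-c3occ(C)c3C(=O)On3nnc4ccccc43)ccc12` differs from compound 2 at a different place than compound 3 does: a group of 9 heavy atoms (6 carbon, 3 nitrogen; one five-membered aromatic ring with 3 hetero atoms, one six-membered aromatic ring of carbon only) in place of a group of 3 heavy atoms (3 carbon; no ring), on an oxygen next to a carbonyl group. For the measured compounds named here, no measured step touches that place, and the one step that starts from compound 2 gives no firm direction. Compound 4 is therefore estimated at 8 ug/mL, with a range from 3 ug/mL to 20 ug/mL. The expected step is an at least 1.2-fold lower number from compound 2 to compound 4 (0.09 log units; that floor lies within the scatter), and a limit result is again thought likely.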

Compound 4, concentration for half-maximal effect: > 10 ug/mL
Compound 4 was reported as a limit; the forecaster's own chance of this, stated with the estimate: 40%; middle value at least 1.2-fold (0.09 log units) away from the limit.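

In this assay compound 4 is reported only as a limit of the assay, > 10 ug/mL. Among the compounds shown here, compound 2 is also reported as a limit, so no step between compound 2 and compound 4 can be read: the limit of > 10 ug/mL in this assay, at which 2 of the 4 values shown sit. The compounds shown leave open whether replacing the propyl group on the ester oxygen changes the effect at all.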